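Swapping a Methylphenyl Group for a Phenethyl Chain

A few compounds are considered here, and "the series" means these few. Any claim that something is new, unique, unknown or untested is made for them only; others in the source may bear on it.

Three compounds sharing a fused two-ring core were tested in a functional assay on CCRF-CEM cells (Homo sapiens) for inhibition, read by cell counting, with a stated time of 3 days; a lower number here means a stronger inhibitor, a higher number a weaker inhibitor. Compound 1 `COc1cccc(-c2nn3cc(-c4cccc(N)c4)nc3s2)c1` gives only a limit, > 250000 nM, so no number is known for it; this is the case described by the limit of > 250000 nM in this assay, at which 1 of the 3 values shown sits. Compound 3 `Nc1cccc(-c2cn3c(-c4ccc(Cl)cc4)csc3n2)c1` gives 21000 nM. Compound 2 `C=C(Br)C(=O)Nc1cccc(-c2cn3nc(-c4ccc(C)cc4)sc3n2)c1` gives 1700 nM, the lowest of the two numbers shown; compound 3, its nearest neighbour, lies well above it, beyond the usual scatter of this assay. For the measured compounds named here, the two differ in more than one place, so no single step between them can be read off.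

Compound 4 `C=C(Br)C(=O)Nc1cccc(-c2cn3nc(CCc4ccccc4)sc3n2)c1` has not yet been measured. It differs from compound 2 in one place: phenethyl in place of 4-methylphenyl on an aromatic carbon. Going by the values given here, no measured pair in this set shows what such an exchange does in this assay, so the expectation rests only on the starting point of compound 2. Replacing a flat aromatic substituent with a short flexible chain is a change of shape more than of polarity, and a modest loss of potency is the expected outcome. The step from compound 2 to compound 4 is expected to be a 2.4-fold higher number from compound 2 to compound 4 (0.37 log units; beyond the scatter). Compound 4 is therefore estimated at 4000 nM, within a range from 1000 nM to 20000 nM.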

Compound 4, half-maximal inhibitory concentration: 4200 nM
Compound 4: middle estimate off by 1.1-fold (0.02 log units), on the low side, within the range that was stated.
By their numbers in this assay, from the lowest: compound 2; then compound 4; then compound 3. At a limit, above all of these: compound 1.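

For the compounds shown here, this is the first step here that changes a single place, so it gives the first direct reading of the aromatic carbon next to the ring nitrogen and next to the ring sulfur: in this assay putting phenethyl in place of 4-methylphenyl gives a 2.5-fold higher number from compound 2 to compound 4 (0.39 log units; beyond the scatter) on the shared core. Both groups carry one six-membered aromatic ring of carbon only, and the heavy atoms go from 7 to 8, so at this position the exchange costs only a modest step, though one beyond the usual scatter, and compound 4 keeps a measurable number in the same assay. No measurement shown here offers a reason for the size of this step.

Going by these compounds, one exchange at one position cannot show a trend, so it remains open how the number would respond to a benzyl group, a longer chain such as phenylpropyl, or a chain ending in an amine or a carboxylic acid. On these data alone, compound 2 and compound 4 also share the same bromine-bearing amide, so what that group contributes stays open as well.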